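Removing the Methyl from Compound 2: An Open Expectation

This account rests on a few compounds, and the source may have more. Where it says the series, first, only, none or still open, it means among the compounds named here.

Compound 2 `COc1ccc2nc(Nc3nc(Nc4ccc(S(N)(=O)=O)cc4)ncc3C)sc2c1` gives 7860 nM in a functional assay on HCT-116 cells (Homo sapiens) for antiproliferative activity, read by MTT assay, with a stated time of 48 h (on this read-out lower numbers stand for stronger inhibition and higher numbers for weaker inhibition), the higher of the two numbers recorded so far, while compound 1 `Cc1cnc(Nc2ccc(S(N)(=O)=O)cc2)nc1Nc1nc2ccccc2s1` gives 1660 nM. Going by the values given here, the only measured step, a 4.7-fold higher number from compound 1 to compound 2 (0.68 log units; beyond the scatter), concerns a methoxy group and says nothing about the methyl. Compound 3 `COc1ccc2nc(Nc3ccnc(Nc4ccc(S(N)(=O)=O)cc4)n3)sc2c1` differs from compound 2 by hydrogen in place of methyl on an aromatic carbon. Among the compounds with values here, no measured step bears on this change, so the direction in this assay is unknown and only a small step is expected. Compound 3 is therefore estimated at 7000 nM, within a range from 2000 nM to 25000 nM. For compound 3 this expectation amounts to a step of a 1.1-fold lower number from compound 2 to compound 3 (0.05 log units; within the scatter).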

Compound 3, half-maximal inhibitory concentration: 1480 nM
Compound 3: middle estimate off by 4.7-fold (0.67 log units), on the high side; measured number outside the range, below it.
By their numbers in this assay, from the lowest: compounds 3 and 1 (each within the scatter of the next); then compound 2.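

In this assay, hydrogen in place of methyl on this aromatic carbon gives a 5.3-fold lower number from compound 2 to compound 3 (0.73 log units; beyond the scatter). The position therefore responds to a small change: losing a methyl, a single heavy atom, moves the number beyond the scatter when the methoxy group is present. Nothing measured here gives a cause for this shift. Still open, as far as these compounds go, is whether the same change would have a similar effect in compound 1, which lacks the methoxy group. From the compounds shown here alone, it is also open how an amine or a longer chain on this carbon would compare with methyl and hydrogen.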